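The source may hold more compounds than are shown below. What is called first, only, known or untested is meant among the compounds shown, and "the series" means these compounds.

Measured so far:
- compound 1 `[O-][S+](CCNC1CCN(CC(O)Cc2ccccc2)CC1)C(c1ccc(F)cc1)c1ccc(F)cc1`: in an assay on membranes from striatum (strain Sprague-Dawley) for displacement of a labelled ligand from sodium-dependent dopamine transporter (Rattus norvegicus), read by scintillation counting, with a stated time of 120 min (a higher number here means a weaker inhibitor, a lower number a stronger inhibitor), compound 1 gives 91.8 nM
- compound 2 `O=C(c1ccccc1)N1CCC(NCCSC(c2ccc(F)cc2)c2ccc(F)cc2)CC1`: in this assay compound 2 gives 4.51 nM
- compound 3 `O=C(c1ccccc1)N1CCC(NCC[S+]([O-])C(c2ccc(F)cc2)c2ccc(F)cc2)CC1`: in this assay compound 3 gives 79.1 nM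

Compound 2 stands lowest of the three numbers; its nearest neighbour is compound 3, and compound 1 lies furthest, both beyond the scatter. Compound 2 and compound 3 are not joined by a counted step; their two values simply show that the sulfide gives the lower number.

Compound 4 `CC(C)(C)CN1CCC(NCCSC(c2ccc(F)cc2)c2ccc(F)cc2)CC1` is not yet measured. It differs from compound 2 in one place: neopentyl in place of benzoyl on an amine nitrogen in a ring.

Within the data shown here, one measured step bears on a change of the group on the ring nitrogen: a 1.2-fold lower number from compound 1 to compound 3 (0.06 log units; within the scatter). That step, in the sulfoxide pair, exchanged the nitrogen substituent without moving the number beyond the scatter. Among the measured compounds shown here, no measured pair exchanges benzoyl for neopentyl, so the carbonyl's loss is untested here. On the step from compound 2 to compound 4 in this assay no change beyond the scatter is therefore expected, with a wide range to cover the untested part of the change, expected as a 1.3-fold higher number from compound 2 to compound 4 (0.12 log units; within the scatter).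

Compound 4 is estimated at 6 nM, expected between 2 nM and 25 nM.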

Compound 4, inhibition constant: 279 nM
For compound 4 the middle estimate is 47-fold (1.67 log units) below the measured one; the whole stated range lies below it.
By their numbers in this assay, from the lowest: compound 2; then compounds 3 and 1 (each within the scatter of the next); then compound 4.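

In this assay the group on the ring nitrogen matters strongly in the sulfide pair, with a 62-fold higher number from compound 2 to compound 4 (1.79 log units; beyond the scatter) as benzoyl gives way to neopentyl. Among these compounds, the only earlier exchange at this nitrogen, a 1.2-fold lower number from compound 1 to compound 3 (0.06 log units; within the scatter) in the sulfoxide pair, involved different groups and stayed within the scatter, so the position is not indifferent to its substituent. No measurement to hand accounts for the size of the new step.

Benzoyl leaves with both its aromatic ring and its carbonyl, and a benzyl group, keeping the ring alone, or a pivaloyl group, keeping the carbonyl alone, would separate the two. Also open, from the compounds shown here alone, is whether neopentyl on the sulfoxide would give a step of similar size.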